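Chlorophenyl urea series: shifting chlorine on the aryl nitrogen

The source may report more compounds than this note shows. Statements on the series, on what has been measured and on what is new or still open speak of the compounds shown alone.

Compound 1 `COc1ccc(NC(=O)NC2CC(C)(C)Oc3ccc(Br)cc32)cc1` reaches only > 10000 nM in a functional assay (aorta) with Rattus norvegicus as the target (a lower number here means that less compound is needed, a higher number that more compound is needed for the effect), which is a limit of the assay and not a number. Compound 2 `CC1(C)CC(NC(=O)Nc2ccccc2Cl)c2cc(Br)ccc2O1` gives > 30000 nM in this assay, again a limit. The step that the two limits leave unreadable from compound 1 to compound 2 is therefore unreadable, both values sitting at limits (the limit of > 10000 nM in this assay, at which 1 of the 2 values shown sits, (the limit of > 30000 nM in this assay, at which 1 of the 2 values shown sits)). Compound 3 `CC1(C)CC(NC(=O)Nc2cccc(Cl)c2)c2cc(Br)ccc2O1` differs from compound 2 by 3-chlorophenyl in place of 2-chlorophenyl on an amide-type nitrogen. No readable measured step bears on this change, and compound 2 itself stands at a limit. Compound 3 is expected to stay near that limit, with a step of a number no higher from compound 2 to compound 3 (the limit leaves the size open) of no clear direction. The estimate for compound 3 in this assay is 30000 nM, within 8000 nM to 100000 nM.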

Compound 3, half-maximal effective concentration: > 30000 nM
Compound 3: only a limit was reported (the forecaster's own chance of this, stated with the estimate: 75%); the middle value sits exactly at the limit.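

Among these compounds, compound 1, compound 2 and compound 3 all stand at limits of this assay, not at numbers, so no step among them can be read. The compounds shown leave open whether 2-chlorophenyl, 3-chlorophenyl and 4-methoxyphenyl differ at all.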